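Coumarin-pyrazoline series: cytotoxicity notes toward compound 4

A few compounds are considered here, and "the series" means these few. Any claim that something is new, unique, unknown or untested is made for them only; others in the source may bear on it.

Measured compounds:
compound 1 `COc1ccc2ccc(=O)oc2c1C1=NNC(c2ccc(SC)cc2)C1`: 10 nM
compound 2 `COc1ccc2ccc(=O)oc2c1C1=NN(C(N)=O)C(c2cccs2)C1`: 26 nM
compound 3 `COc1ccc2ccc(=O)oc2c1C1=NN(c2ccccc2)C(c2cccs2)C1`: 15 nM

In a functional assay on HepG2 cells (Homo sapiens) for cytotoxicity, read by MTT assay, with a stated time of 72 h (a lower number here means a stronger inhibitor, a higher number a weaker inhibitor), compound 3 gives 15 nM and stands second highest of the three numbers; its gaps to compound 1 and to compound 2 are both within the scatter, so no order among the three can be claimed. Among the compounds with values here, the only single-point step measured is a 1.7-fold lower number from compound 2 to compound 3 (0.24 log units; within the scatter), phenyl in place of carbamoyl on the ring nitrogen, and it stays within the scatter.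

Compound 4 `COc1ccc2ccc(=O)oc2c1C1=NN(c2ccccc2)C(c2ccc(C)cc2)C1` differs from compound 3 by 4-methylphenyl in place of thiophen-2-yl on a saturated ring carbon. Within the data shown here, no measured step exchanges the group on that saturated ring carbon while the rest is held fixed; compound 1 carries a different group there and a different ring nitrogen, so its value speaks only in general terms. With every measured step and gap within the scatter, the expectation for compound 4 in this assay is a step of no change at the digits printed from compound 3 to compound 4 (within the scatter), not beyond the scatter in either direction. Compound 4 is therefore estimated at 15 nM, with a range from 6 nM to 40 nM.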

Compound 4, half-maximal inhibitory concentration: 51 nM
Compound 4: the middle estimate sits 3.4-fold (0.53 log units) below what was measured; the whole stated range lies below it.
By their numbers in this assay, from the lowest: compounds 1, 3, 2 and 4 (each within the scatter of the next, the first and the last beyond it).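

In this assay, within the data shown here, the saturated ring carbon next to the ring nitrogen gives the first single change that lies beyond the scatter: 4-methylphenyl in place of thiophen-2-yl is a 3.4-fold higher number from compound 3 to compound 4 (0.53 log units; beyond the scatter). The only earlier step, on the ring nitrogen, stayed within the scatter, so this carbon is the one place shown where an exchange registers, here with the phenyl on the ring nitrogen held fixed. Nothing at hand accounts for the size or direction of this step.

Going by these compounds, whether the step belongs to the change of ring or to the methyl stays open; a plain phenyl or a 4-aminophenyl on that carbon would help separate the two. Also open, on these data alone, is whether the same exchange gives a similar step with carbamoyl on the ring nitrogen.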